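Swapping bromo for fluoro on compound 1

The source may hold more compounds than are shown below. What is called first, only, known or untested is meant among the compounds shown, and "the series" means these compounds.

Among the compounds with values here, in a functional assay on MGC-803 cells (Homo sapiens) for inhibition, read by MTT assay, with a stated time of 48 h (a higher number here means a weaker inhibitor, a lower number a stronger inhibitor), compound 1 (`COc1ccc(CNc2cc(OC)c(OC)c(OC)c2)cc1Br`) gives 29400 nM, the highest number of the three compounds measured so far. By comparison, compound 3 (`C/C=C/C(=O)N(Cc1ccc(OC)c(Br)c1)c1cc(OC)c(OC)c(OC)c1`) gives 6430 nM and compound 2 (`C#CC(=O)N(Cc1ccc(OC)c(O)c1)c1cc(OC)c(OC)c(OC)c1`) gives 170 nM. Compound 4 (`COc1ccc(CNc2cc(OC)c(OC)c(OC)c2)cc1F`) has not yet been measured. Its change from compound 1 is small: fluoro in place of bromo on an aromatic carbon. In words, this is fluoro in place of bromo on an aromatic carbon, ortho to a methoxy group.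

Within the data shown here, only one measured step starts from compound 1: a 4.6-fold lower number from compound 1 to compound 3 (0.66 log units; beyond the scatter). That step places (prop-1-en-1-yl)carbonyl on the nitrogen and keeps the bromo, so it says nothing direct about this swap. Compound 2 differs from compound 1 in more than one place, so it gives no clean comparison either. Among the measured compounds shown here, with no measured step at this position, no change beyond the scatter is expected in this assay, in either direction. The estimated step is a 1.0-fold higher number from compound 1 to compound 4 (0.01 log units; within the scatter). The expected value for compound 4 is 30000 nM, within an estimated range of 12000 nM to 70000 nM.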

Compound 4, half-maximal inhibitory concentration: 39700 nM
Compound 4: middle estimate off by 1.3-fold (0.12 log units), on the low side; the range from low to high includes it.
By their numbers in this assay, from the lowest: compound 2; then compound 3; then compounds 1 and 4 (each within the scatter of the next).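

In this assay, within the data shown here, this is the first clean reading of the position ortho to a methoxy group: a 1.4-fold higher number from compound 1 to compound 4 (0.13 log units; within the scatter). Fluoro in place of bromo therefore produces no difference that can be separated from ordinary assay scatter, even though the two halogens are different atoms. By contrast, placing a (prop-1-en-1-yl)carbonyl group on the nitrogen gives a step beyond the scatter, a 4.6-fold lower number from compound 1 to compound 3 (0.66 log units; beyond the scatter), so in this small set the nitrogen change registers and the halogen swap does not; no measurement here offers an explanation for the halogen result.

From the compounds shown here alone, whether an amine or a carboxylic acid at this position would also leave the number unchanged remains open. It is also unknown whether fluoro and bromo would still match with the (prop-1-en-1-yl)carbonyl group on the nitrogen.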